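Fluorophenyl isomer of compound 1: working notes

This account rests on a few compounds, and the source may have more. Where it says the series, first, only, none or still open, it means among the compounds named here.

Within the data shown here, in a functional assay on HCT-8 cells (Homo sapiens) for antiproliferative activity, read by sulforhodamine B assay, with a stated time of 48 h (a lower number here means a stronger inhibitor, a higher number a weaker inhibitor), compound 1 `COc1ccc(/C=C/C(=O)c2ccccc2-c2ccc(F)cc2)cc1` gives 230 nM, the highest of the three numbers so far. Compound 2 `COc1ccc(/C=C/C(=O)c2ccccc2-c2ccc(F)cc2)cc1B(O)O` gives 84 nM, and compound 3 `CN(C)c1ccc(/C=C/C(=O)c2ccccc2-c2ccc(F)cc2)cc1` gives 96 nM. Two modest steps are therefore measured from the same starting point. The first is a 2.7-fold lower number from compound 1 to compound 2 (0.44 log units; beyond the scatter), with a new group in place of a hydrogen atom on an aromatic carbon. The second, with dimethylamino in place of methoxy on an aromatic carbon, is a 2.4-fold lower number from compound 1 to compound 3 (0.38 log units; beyond the scatter).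

Compound 4 `COc1ccc(/C=C/C(=O)c2ccccc2-c2cccc(F)c2)cc1` is not yet measured. It has the same atoms as compound 1, joined differently: 3-fluorophenyl in place of 4-fluorophenyl on an aromatic carbon. The change is 3-fluorophenyl in place of 4-fluorophenyl on an aromatic carbon, ortho to a large group.

Neither measured step alters the fluorophenyl group, so the data contain no direct measure of this change and offer no basis for a direction. They show only the size of two other single changes in the series. With compound 1 at 230 nM as the anchor, no step beyond the scatter is expected in this assay. The estimated step is a 1.1-fold higher number from compound 1 to compound 4 (0.04 log units; within the scatter). For compound 4 the estimate is 250 nM, with an expected range of 100 nM to 650 nM.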

Compound 4, half-maximal inhibitory concentration: 220 nM
Compound 4: the middle estimate sits 1.1-fold (0.06 log units) above what was measured; measured number inside the range.
By their numbers in this assay, from the lowest: compounds 2 and 3 (each within the scatter of the next); then compounds 4 and 1 (each within the scatter of the next).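

Among these compounds, compound 4 gives the first measured change to the fluorophenyl group: in this assay, 3-fluorophenyl in place of 4-fluorophenyl, ortho to a large group, gives a 1.0-fold lower number from compound 1 to compound 4 (0.02 log units; within the scatter). The two isomers therefore cannot be told apart in this assay, so moving fluorine between these two places on the ring has no readable effect on the number. The two changes made outside the fluorophenyl group, a 2.7-fold lower number from compound 1 to compound 2 (0.44 log units; beyond the scatter) and a 2.4-fold lower number from compound 1 to compound 3 (0.38 log units; beyond the scatter), both lie beyond the scatter, so within these compounds only those changes shift the reading, and no measurement available here bears on why the two fluorine isomers read alike.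

On these data alone, it remains open whether the fluorine itself contributes at all, or whether chlorine, a methoxy group or an amine on this ring would leave the number just as unchanged. Also open, as far as these compounds go, is whether the same isomer swap would read alike on the core of compound 2 or compound 3, which carry the boron-containing group and the dimethylamino group.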